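The source may report more compounds than this note shows. Statements on the series, on what has been measured and on what is new or still open speak of the compounds shown alone.

Values so far in a functional assay on Bel-7402 cells (Homo sapiens) for inhibition, read by MTT assay (a higher number here means a weaker inhibitor, a lower number a stronger inhibitor), as measured:
- compound 1 `C=C1C(=O)[C@@]23C(=O)OC[C@]4([C@@H](OC(C)=O)CCC(C)(C)[C@H]4C=O)[C@@H]2CC[C@H]1[C@H]3OC(=O)c1ccc(Cl)cc1` gives 1510 nM
- compound 2 `C=C1C(=O)[C@@]23C(=O)OC[C@]4([C@@H](OC(C)=O)CCC(C)(C)[C@H]4C=O)[C@@H]2CC[C@H]1[C@H]3OC(C)=O` gives 3960 nM

Among the compounds with values here, compound 1 holds the lower of the two numbers, which makes it the stronger inhibitor of this pair in this assay so far. Compound 3 `C=C1C(=O)[C@@]23C(=O)OC[C@]4([C@@H](OC(C)=O)CCC(C)(C)[C@H]4C=O)[C@@H]2CC[C@H]1[C@H]3OC(=O)CCCC` has not yet been measured. It keeps the core of compound 1 and changes a single group: butyl in place of 4-chlorophenyl on a carbonyl carbon. Put simply, this is butyl in place of 4-chlorophenyl on a carbonyl carbon.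

Within the data shown here, one measured step bears on this change. At the same place, methyl in place of 4-chlorophenyl gave a 2.6-fold higher number from compound 1 to compound 2 (0.42 log units; beyond the scatter) and this is a modest move toward weaker inhibition. Butyl, like methyl, has no ring, so a modest step in the same direction is expected, perhaps a smaller one. Among the measured compounds shown here, no measured compound carries butyl, and a single step is thin evidence, so the range stays wide. The expected change is a 1.7-fold higher number from compound 1 to compound 3 (0.22 log units; within the scatter) as an estimate. Compound 3 is thus expected at 2500 nM with an estimated range from 1100 nM to 5500 nM in this assay.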

Compound 3, half-maximal inhibitory concentration: 3640 nM
Estimate against measurement, compound 3: 1.5-fold (0.16 log units) below; low and high end bracket the measured number.
By their numbers in this assay, from the lowest: compound 1; then compounds 3 and 2 (each within the scatter of the next).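

In this assay, butyl in place of 4-chlorophenyl gives a 2.4-fold higher number from compound 1 to compound 3 (0.38 log units; beyond the scatter), so the methyl result no longer stands alone: two groups without a ring now both give a higher number than compound 1. Going from the methyl of compound 2 to the butyl of compound 3 gives a 1.1-fold lower number from compound 2 to compound 3 (0.04 log units; within the scatter), which means that these two chains cannot be told apart at this position and that chain length over this span shows no clear effect. Nothing measured here accounts for the gap between the 4-chlorophenyl compound and the two chain compounds.

Compared with both chains, 4-chlorophenyl carries a ring and a chlorine, and the compounds shown do not separate these two features, which a plain phenyl group on the same carbonyl carbon could begin to do. Also open, from the compounds shown here alone, is how a chain longer than butyl, or a group carrying an amine or a carboxylic acid, would read in this assay.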